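The source may report more compounds than this note shows. Statements on the series, on what has been measured and on what is new or still open speak of the compounds shown alone.

Measured so far:
- compound 1, `Fc1ccc(/C=N/c2sc3c(c2-c2nc4ccccc4s2)CCC3)cc1`: 372 ug/mL
- compound 2, `Fc1ccccc1/C=N/c1sc2c(c1-c1nc3ccccc3s1)CCCC2`: 426 ug/mL

In an ADME assay on HeLa cells (Homo sapiens) for cytotoxicity, read by MTT assay, with a stated time of 72 h (a higher number here means that more compound is tolerated, a lower number that less compound is tolerated), compound 1 gives 372 ug/mL and compound 2 gives 426 ug/mL; the two numbers lie within the scatter of each other, so nothing separates them in this assay. Both share the same core carrying an imine-linked fluorophenyl group; compound 1 carries a five-membered saturated ring fused to the core, compound 2 a six-membered one, and the fluoro sits in a different position on the phenyl ring of each.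

Compound 3, `Oc1ccccc1/C=N/c1sc2c(c1-c1nc3ccccc3s1)CCCC2`, has not been measured. It differs from compound 2 in one place: hydroxy in place of fluoro on an aromatic carbon, the hydroxy sitting ortho to a large group on the six-membered aromatic ring of carbon only. No measured pair in the series isolates a change of this kind, so no step size can be drawn from the numbers shown.

The expectation is that the step from compound 2 to compound 3 in this assay, a 1.1-fold lower number from compound 2 to compound 3 (0.03 log units; within the scatter), stays within the scatter, with no direction implied. For compound 3 the estimated value is 400 ug/mL, with a range from 240 ug/mL to 650 ug/mL.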

Compound 3, half-maximal cytotoxic concentration: 122 ug/mL
Beside the measured number, compound 3's estimate is 3.3-fold (0.52 log units) above it, and the stated range ends above it.
By their numbers in this assay, from the lowest: compound 3; then compounds 1 and 2 (each within the scatter of the next).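

In this assay, going by these compounds alone, hydroxy in place of fluoro on an aromatic carbon, ortho to a large group, gives a 3.5-fold lower number from compound 2 to compound 3 (0.54 log units; beyond the scatter) and so provides the first step that lies beyond the scatter. The place on the six-membered aromatic ring of carbon only is therefore not indifferent to its group: less compound is tolerated with 2-hydroxyphenyl than with 2-fluorophenyl, on an otherwise unchanged structure, something that compound 1 and compound 2 could not show, as they differ in more than one place. The change adds one hydrogen-bond donor and one hydrogen-bond acceptor, but nothing measured here connects either count, or any other feature of the change, to the step.

Going by these compounds, whether the step is specific to hydroxy remains open, since a methoxy or an amine on the same aromatic carbon would test how far it extends beyond this one group. Also open, on these data alone, is whether the same change carries the same step on the five-membered saturated ring of compound 1, or at other places on the phenyl ring.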